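The source may report more compounds than this note shows. Statements on the series, on what has been measured and on what is new or still open speak of the compounds shown alone.

Measured so far:
compound 1 `Cc1ccc(SCc2ccc(/C=C/C(=O)Nc3ccccc3N)cc2)cc1` — 48.3%
compound 2 `Nc1ccccc1NC(=O)c1ccc(CSc2nccc(C(F)(F)F)n2)cc1` — 95.1%

In a functional assay on A549 cells (Homo sapiens) for inhibition, read by CCK-8 assay, with a stated time of 72 h, tested at 8 uM (on this read-out lower numbers stand for less inhibition of growth and higher numbers for more inhibition of growth at the one concentration tested), compound 1 gives 48.3%, the lower of the two numbers, while compound 2 gives 95.1%, a gap beyond the usual scatter. Compound 3 `Nc1ccccc1NC(=O)/C=C/c1ccc(CSc2ccc(F)cc2)cc1` differs from compound 1 by fluoro in place of methyl on an aromatic carbon. Among the measured compounds shown here, no measured pair shows this exchange, so its effect cannot be read from the data. In this assay the step is expected to be small, within the scatter, in no clear direction: a number 1.7 percentage points higher from compound 1 to compound 3 (within the scatter). Compound 3 is therefore estimated at 50%, with a range from 30% to 70%.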

Compound 3, percent growth inhibition at one concentration: 59.1%
Beside the measured number, compound 3's estimate is 9.1 percentage points below it, and the stated range covers the measured number.
By their numbers in this assay, from the lowest: compound 1; then compound 3; then compound 2.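

Among the compounds shown here, the step of a number 10.8 percentage points higher from compound 1 to compound 3 (beyond the scatter) in this assay is the first single-place comparison, with fluoro in place of methyl on an aromatic carbon, para to a large group. It shows that this position responds to a one-atom exchange, though only modestly. No measured evidence accounts for the step.

For the compounds shown here, with only one exchange at this position, the trend remains open; chloro, methoxy or an amine there could show whether fluoro is unusual. Compound 2 differs from the others in more than one place, so its value cannot be assigned to any single change.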